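This account rests on a few compounds, and the source may have more. Where it says the series, first, only, none or still open, it means among the compounds named here.

Of the compounds shown here, three have been measured in a functional assay on HepG2 cells (Homo sapiens) for cytotoxicity, with a stated time of 24 h; a lower number here means a stronger inhibitor, a higher number a weaker inhibitor. Compound 1 `O=C(N/N=C/c1cc(I)cc(I)c1O)c1ccc(O)cc1` gives 19200 nM in this assay. Compound 3 `O=C(NNC(=O)c1cc(I)cc(I)c1O)c1ccccc1` gives 98000 nM in this assay. Compound 2 `O=C(N/N=C/c1cc(I)c(O)c(I)c1)c1ccc(I)cc1` returns only > 50000 nM in this assay, which is a limit of the assay and not a number, as set out in the limit of > 50000 nM in this assay, at which 1 of the 3 values shown sits. Of the two compounds with a number, compound 3 has the higher one, and its gap to compound 1 lies beyond the usual scatter of the measurement.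

Compound 4 `O=C(NNC(=O)c1cc(I)cc(I)c1O)c1ccc(F)cc1` differs from compound 3 by a single change: fluoro in place of hydrogen on an aromatic carbon. Going by the values given here, no measured pair shows this same change, so the size of the step can only be expected, not read off. The expected step in this assay is a 1.2-fold lower number from compound 3 to compound 4 (0.09 log units; within the scatter), a change that would stay within the usual scatter, with no clear direction. Compound 4 is therefore estimated at 80000 nM in this assay, with a range from 30000 nM to 200000 nM.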

Compound 4, half-maximal inhibitory concentration: 87000 nM
Estimate against measurement, compound 4: 1.1-fold (0.04 log units) below; measured number inside the range.
By their numbers in this assay, from the lowest: compound 1; then compounds 4 and 3 (each within the scatter of the next).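

In this assay, going by these compounds alone, the change from phenyl to 4-fluorophenyl provides the first comparison between compounds that differ in only one place: a 1.1-fold lower number from compound 3 to compound 4 (0.05 log units; within the scatter). At this position, para to a large group, fluoro in place of hydrogen on an aromatic carbon therefore produces no change that can be told apart from the scatter of the measurement. Nothing in the data at hand accounts for this outcome.

The compounds shown leave open whether a different group at this position, such as an amine, a carboxylic acid or a methoxy group, would shift the number beyond the scatter. They also leave open whether fluoro in place of hydrogen would have the same small effect on the core of compound 1.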